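Trading 3-chlorobenzyl for 4-methylbenzyl on a shared core

The source may hold more compounds than are shown below. What is called first, only, known or untested is meant among the compounds shown, and "the series" means these compounds.

Measured compounds in a functional assay on A2780 cells (Homo sapiens) for antiproliferative activity, read by resazurin assay, with a stated time of 72 h; on this read-out lower numbers stand for stronger inhibition and higher numbers for weaker inhibition:
- compound 1 `NC(=O)c1cc2c(Cc3ccccc3)n[nH]c2cc1O`: "not determined" (no result reported)
- compound 2 `CN(Cc1cccc(Cl)c1)C(=O)c1cc2c(Cc3ccccc3)n[nH]c2cc1O`: 5300 nM

For the measured compounds named here, compound 2 holds the only number so far, since compound 1 has the entry "not determined" (no result reported) and so offers nothing to compare. A single value cannot show whether compound 2 is strong or weak within this family, and no trend can be read from it. It serves only as a starting point.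

The next compound to be tested is compound 3 `Cc1ccc(CN(C)C(=O)c2cc3c(Cc4ccccc4)n[nH]c3cc2O)cc1`. It keeps the core and the amide of compound 2 and changes one group: 4-methylphenyl in place of 3-chlorophenyl on a saturated chain carbon bound to an amide-type nitrogen. In words, 4-methylphenyl takes the place of 3-chlorophenyl on a saturated chain carbon bound to an amide-type nitrogen. Going by the values given here, the ring stays and only its substituent differs, and no measured pair yet shows what such a swap does in this assay. Among the compounds with values here, the best guide is therefore compound 2 at 5300 nM, with no step expected beyond the scatter, in either direction.

The expected change is a 1.1-fold lower number from compound 2 to compound 3 (0.03 log units; within the scatter). For compound 3 the estimated value is 5000 nM, with an expected range from 2000 nM to 12000 nM.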

Compound 3, half-maximal inhibitory concentration: 6900 nM
Compound 3: middle estimate off by 1.4-fold (0.14 log units), on the low side; the range from low to high includes it.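

In this assay, putting 4-methylphenyl in place of 3-chlorophenyl on a saturated chain carbon bound to an amide-type nitrogen gives a 1.3-fold higher number from compound 2 to compound 3 (0.11 log units; within the scatter), so this first measured pair in the series shows two compounds that cannot be told apart. The swap replaces chlorine with methyl and also alters the number of the ring position that carries the substituent, yet the result stays within the usual scatter, so this single pair cannot show whether each alteration alone would matter little or whether the two offset each other. No measurement shown here gives a reason for this result.

A 4-chlorophenyl or a 3-methylphenyl group would separate the identity of the substituent from its ring position, and those two groups lie outside the compounds shown. Also open, on these data alone, is what happens when the ring itself is replaced, for example by a longer alkyl chain or by a chain ending in an amine or a carboxylic acid.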